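From 4-bromophenyl to 2-hydroxyphenyl: an expected small step

The compounds below may be only part of what the source reports. "The series", "measured", "known", "first", "only" and "open" are said of these compounds alone.

Measured so far:
compound 1 `Clc1cccc(CSc2nnc(-c3ccncc3)n2-c2ccccc2)c1`: 10500 nM
compound 2 `O=C(CSc1nnc(-c2ccncc2)n1-c1ccccc1)N/N=C/c1ccc(Br)cc1`: 7040 nM

Both compounds share the same core and were tested in a functional assay on MCF7 cells (Homo sapiens) for inhibition, read by MTT assay, with a stated time of 48 h; on this read-out lower numbers stand for stronger inhibition and higher numbers for weaker inhibition. In this assay compound 1 gives 10500 nM. Compound 2 gives 7040 nM, the lower of the two numbers, though its gap to compound 1 lies within the usual scatter, so neither can be called the more active.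

The next compound, compound 3 `O=C(CSc1nnc(-c2ccncc2)n1-c1ccccc1)N/N=C/c1ccccc1O`, keeps everything of compound 2 except one group: 2-hydroxyphenyl in place of 4-bromophenyl on a carbon with a double bond to nitrogen. Among the compounds with values here, no pair of measured compounds differs in just this way, so there is no measured step to lean on. Because compound 2 gives 7040 nM and compound 1 gives 10500 nM, and these sit close together, the expected step from this change is small, with no clear direction beyond the scatter. The expected step is a 1.1-fold higher number from compound 2 to compound 3 (0.06 log units; within the scatter). Compound 3 is therefore expected to give about 8000 nM, within 3000 nM to 25000 nM.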

Compound 3, half-maximal inhibitory concentration: 10000 nM
Beside the measured number, compound 3's estimate is 1.3-fold (0.10 log units) below it; low and high end bracket the measured number.
By their numbers in this assay, from the lowest: compounds 2, 3 and 1 (each within the scatter of the next).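

In this assay, putting 2-hydroxyphenyl in place of 4-bromophenyl on a carbon with a double bond to nitrogen gives a 1.4-fold higher number from compound 2 to compound 3 (0.15 log units; within the scatter) at this position, the first step measured here. Two groups of the same heavy-atom count, one with bromine and no hydrogen-bond donor and the other with oxygen and one donor, therefore cannot be told apart in this read-out. No available measurement explains why this swap leaves the two numbers within the scatter.

From the compounds shown here alone, it stays open whether an amine or a carboxylic acid on the phenyl ring, or a longer chain in place of that ring, would give a step beyond the scatter. A single step also cannot show how plain phenyl would compare with either group.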